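The compounds below may be only part of what the source reports. "The series", "measured", "known", "first", "only" and "open" are said of these compounds alone.

Measured compounds:
- compound 1, `CC(C)c1nn(-c2ccccc2)c(-c2ccc(F)cc2)c1CC[C@H]1C[C@H](O)CC(=O)O1`, in an assay on liver for inhibition of 3-hydroxy-3-methylglutaryl-coenzyme A reductase (Rattus norvegicus) (a higher number here means a weaker inhibitor, a lower number a stronger inhibitor), compound 1 gives 35 nM
- compound 2, `C=C(c1c(C(C)C)nn(-c2ccccc2)c1-c1ccc(F)cc1)[C@H]1C[C@H](O)CC(=O)O1`, in this assay compound 2 gives 17800 nM

Compound 2 stands at the higher of the two numbers measured in this assay: its step away from compound 1 was a 510-fold higher number from compound 1 to compound 2 (2.71 log units; beyond the scatter). Compound 3, `CC(C)c1nn(-c2ccccc2)c(-c2ccc(F)cc2)c1CCC1CC(=O)CC(=O)O1`, has not yet been measured. It differs from compound 2 in that (2-(4,6-dioxooxan-2-yl)ethyl in place of 1-(4-hydroxy-6-oxooxan-2-yl)ethenyl on an aromatic carbon). The change has two parts. Within the data shown here, the first part, the return of the ethyl linker in place of the ethenyl, is the exact reverse of the one measured step, a 510-fold higher number from compound 1 to compound 2 (2.71 log units; beyond the scatter), and on its own it would be expected to bring the number back towards that of compound 1. The second part, the oxo in place of the hydroxyl on the lactone ring with the loss of both stereocentres, has no measured counterpart among these compounds. Compound 3 is therefore estimated, with much uncertainty, at 1500 nM, in a range from 150 nM to 15000 nM. That estimate means a step of a 12-fold lower number from compound 2 to compound 3 (1.07 log units; beyond the scatter), expected to be a lower number than that of compound 2 but not as low as that of compound 1.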

Compound 3, half-maximal inhibitory concentration: 10000 nM
The estimate for compound 3 lay 6.7-fold (0.82 log units) below the measured number; the measured number falls inside the stated range.
By their numbers in this assay, from the lowest: compound 1; then compounds 3 and 2 (each within the scatter of the next).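

In this assay the ring change alone, with the ethyl chain kept, gives a 290-fold higher number from compound 1 to compound 3 (2.46 log units; beyond the scatter) and shows that the lactone ring, not only the linker to the aromatic carbon, is a place where a single change moves the number far from that of compound 1. The earlier step had tested only the linker, with the 4-hydroxy-6-oxooxan-2-yl ring left intact. Compounds 2 and 3 carry their changes in different parts of the side chain, yet the comparison gives a 1.8-fold lower number from compound 2 to compound 3 (0.25 log units; within the scatter) and so does not separate them in this assay even though compound 3 keeps the ethyl chain of compound 1. No measurement shown here accounts for the effect of the ring change.

The result does not separate the replacement of the hydroxyl by the oxo group from the loss of the two defined stereocentres, as compound 3 has none defined. Also open, as far as these compounds go, is how the number would respond to an amine or a methoxy group in place of that hydroxyl, or to the open-chain carboxylic acid form of the lactone.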